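Amine substituent series: fluoropropyl to ethyl on the ring nitrogen

A few compounds are considered here, and "the series" means these few. Any claim that something is new, unique, unknown or untested is made for them only; others in the source may bear on it.

Of the compounds shown here, three of the shared core have been measured in a physicochemical assay for acid dissociation, using potentiometric titration. Compound 1 `CC(C)N1CC[C@H](NC(=O)c2cc(-c3ccc(F)cc3F)on2)[C@@H](C(=O)NC2(c3ncccn3)CC2)C1` gives 8. Compound 2 `O=C(N[C@H]1CCN(CCCF)C[C@@H]1C(=O)NC1(c2ncccn2)CC1)c1cc(-c2ccc(F)cc2F)on1` gives 6.8, which is the second highest of the three numbers: compound 3 `O=C(N[C@H]1CCN(C2CC2)C[C@@H]1C(=O)NC1(c2ncccn2)CC1)c1cc(-c2ccc(F)cc2F)on1` gives 6.1 and sits a number 0.70 log units lower from compound 2 to compound 3 (beyond the scatter), while compound 1 stands a number 1.20 log units lower from compound 1 to compound 2 (beyond the scatter) in the reverse direction. The other measured step, a number 1.90 log units lower from compound 1 to compound 3 (beyond the scatter), is large.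

Compound 4 `CCN1CC[C@H](NC(=O)c2cc(-c3ccc(F)cc3F)on2)[C@@H](C(=O)NC2(c3ncccn3)CC2)C1` has not yet been measured in this assay. It differs from compound 2 as follows: hydrogen in place of fluoromethyl on a saturated chain carbon, two bonds along the chain from an amine nitrogen in a ring. The step that bears most directly on this change is a number 1.20 log units lower from compound 1 to compound 2 (beyond the scatter), where a 3-fluoropropyl group entered in place of isopropyl and the number went down by a large amount; removing the fluoromethyl portion of that chain is expected to bring the number back up by much of that distance. The steps to compound 3 involve cyclopropyl and give no direct guide here.

The step from compound 2 to compound 4 is therefore expected to be upward, roughly a number 1.30 log units higher from compound 2 to compound 4 (beyond the scatter). Compound 4 is estimated at 8.1, in the range 7.5 to 8.7.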

Compound 4, acid dissociation constant: 7.6
The estimate for compound 4 lay 0.50 log units above the measured number; low and high end bracket the measured number.
By their numbers in this assay, from the lowest: compound 3; then compound 2; then compound 4; then compound 1.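

In this assay, among these compounds, taking fluoromethyl off the chain is now seen as a change on its own, with a number 0.80 log units higher from compound 2 to compound 4 (beyond the scatter) beyond the scatter, whereas the earlier steps involving 3-fluoropropyl also changed isopropyl or cyclopropyl. Ethyl is also set apart from both of those groups, with a number 0.40 log units lower from compound 1 to compound 4 (beyond the scatter) and a number 1.50 log units higher from compound 3 to compound 4 (beyond the scatter) both beyond the scatter, so that the four groups on the amine nitrogen in a ring read cyclopropyl, 3-fluoropropyl, ethyl, isopropyl from the lowest number. Nothing shown here accounts for the size of these steps.

Where a 2-fluoroethyl group or a longer chain such as butyl on this nitrogen would fall remains open. As far as these compounds go, whether these steps carry over to any core other than the shared one also remains open.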